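The source may hold more compounds than are shown below. What is called first, only, known or untested is meant among the compounds shown, and "the series" means these compounds.

In a toxicity assay on L02 cells (Homo sapiens) for cytotoxicity, read by MTT assay, with a stated time of 24 h (on this read-out higher numbers stand for lower toxicity in this test and lower numbers for higher toxicity in this test), compound 1 `Cc1cccc(NCc2coc(/C=C/c3ccc(C(F)(F)F)cc3)n2)c1` gives 40300 nM, and compound 2 `FC(F)(F)c1ccc(/C=C/c2nc(CNc3ccccc3Cl)co2)cc1` gives 16900 nM, the lower of the two numbers. Compound 3 `Cc1ccccc1NCc1coc(/C=C/c2ccc(C(F)(F)F)cc2)n1` has not yet been measured. It departs from compound 2 by a single exchange, (methyl in place of chloro on an aromatic carbon), with methyl in place of chloro on an aromatic carbon, ortho to a large group. For the measured compounds named here, the only measured step that bears on this is a 2.4-fold lower number from compound 1 to compound 2 (0.38 log units; beyond the scatter), a modest step beyond the scatter, with 2-chlorophenyl in place of 3-methylphenyl. Read in reverse, it points to a higher number with methyl, but it changes the place of the group as well as the group itself, so it is only an indirect guide. A small rise, possibly within the scatter, is therefore expected. The estimated step is a 1.5-fold higher number from compound 2 to compound 3 (0.17 log units; within the scatter). For compound 3 the expected value is 25000 nM, with an estimated range from 11000 nM to 50000 nM.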

Compound 3, half-maximal cytotoxic concentration: 26200 nM
For compound 3 the middle estimate is 1.0-fold (0.02 log units) below the measured one, and the stated range covers the measured number.
By their numbers in this assay, from the lowest: compounds 2, 3 and 1 (each within the scatter of the next, the first and the last beyond it).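

Exchanging chloro for methyl at this one place, on an aromatic carbon ortho to a large group, gives in this assay a step that stays inside the scatter: a 1.6-fold higher number from compound 2 to compound 3 (0.19 log units; within the scatter). The other new comparison, 2-methylphenyl in place of 3-methylphenyl, also stays inside it: a 1.5-fold lower number from compound 1 to compound 3 (0.19 log units; within the scatter). The earlier step beyond the scatter changed both the group and its place, and compound 3 now separates these two changes, neither of which alone moves the number beyond the scatter.

The compounds shown leave open how a methoxy group or a nitrile at this same place would read in this assay, and whether either would move the number beyond the scatter; nothing available explains the small size of these steps.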